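From Phenyl to Methyl: What to Expect for Compound 3

The source may hold more compounds than are shown below. What is called first, only, known or untested is meant among the compounds shown, and "the series" means these compounds.

Compound 1 `Cc1cccc(Nc2cc(Cl)nc(SC(C(=O)O)c3ccccc3)n2)c1C` was tested in an assay for inhibition of Polyunsaturated fatty acid 5-lipoxygenase (Homo sapiens), tested at 1 uM (on this read-out lower numbers stand for a stronger effect and higher numbers for a weaker effect at the one concentration tested), where compound 1 was recorded as "not active" (no number reported), so no single number marks where it stands. A close relative, compound 2 `CCOC(=O)C(Sc1nc(Cl)cc(Nc2cccc(C)c2C)n1)c1ccccc1`, gives 53.1% in this assay. Compound 3 `Cc1cccc(Nc2cc(Cl)nc(SC(C)C(=O)O)n2)c1C` is not yet measured and carries methyl in place of phenyl on a saturated chain carbon bound to a carbonyl carbon and a sulfur. Going by the values given here, no measured step exists for this change, and with compound 1 lacking a number the expectation is simply a high read-out, with any shift staying within the scatter. Compound 3 is expected to give 88%, estimated between 65% and 105%, because compound 1 stands at "not active" (no number reported).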

Compound 3, a percentage reported as activity, at one concentration (the size of the read-out at that concentration, not a potency): "not active" (no number reported)
Compound 3 has no reported number here; no gap can be computed for the estimate.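

Going by these compounds alone, compound 1 and compound 3 both lack a number in this assay, so no step between them can be read. No measured evidence bears on this result. From the compounds shown here alone, how far swapping phenyl for methyl shifts the read-out stays open.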